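Clearance notes: chloro in place of methoxy

The compounds below may be only part of what the source reports. "The series", "measured", "known", "first", "only" and "open" are said of these compounds alone.

Measured so far in an in vitro ADME assay on microsomes from liver (Homo sapiens) for metabolic stability; on this read-out lower numbers stand for slow clearance and higher numbers for fast clearance:
- Compound 1 `Cc1c(Sc2ccc(Cl)cc2)c2cc(-c3ccccc3)ccc2n1CC(=O)O`: 16 mL.min-1.g-1
- Compound 2 `COc1ccc(Sc2c(C)n(CC(=O)O)c3ccc(C)cc23)cc1`: < 3 mL.min-1.g-1

Compound 2 is known only through a limit of the assay, < 3 mL.min-1.g-1, and not through a number. The next compound to be read in this assay is compound 3 `Cc1ccc2c(c1)c(Sc1ccc(Cl)cc1)c(C)n2CC(=O)O`. It carries chloro in place of methoxy on an aromatic carbon, para to a large group (chloro in place of methoxy on an aromatic carbon). Cut one bond further out, the same difference reads 4-methoxyphenyl to 4-chlorophenyl.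

Among the measured compounds shown here, no measured pair isolates this change, so its size has no direct precedent. For the measured compounds named here, the only guide is compound 1 at 16 mL.min-1.g-1, which also carries the 4-chlorophenyl group but differs from compound 3 elsewhere on the shared core. A modest upward move in clearance is therefore expected, and the step of an at least 2.0-fold higher number from compound 2 to compound 3 (0.30 log units; that floor lies within the scatter) is an estimate measured from a limit. Compound 3 is estimated at 6 mL.min-1.g-1, with an expected range from 3 mL.min-1.g-1 to 14 mL.min-1.g-1.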

Compound 3, intrinsic clearance in microsomes: < 3 mL.min-1.g-1
Compound 3 was reported as a limit; the forecaster's own chance of this, stated with the estimate: 30%; middle value at least 2.0-fold (0.30 log units) from the limit.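

In this assay compound 3 sits at a limit of the assay, < 3 mL.min-1.g-1, so 4-chlorophenyl in place of 4-methoxyphenyl does not lift this compound clear of that limit. The size of the change from methoxy to chloro on the aromatic carbon cannot be read, because compound 2 and compound 3 both sit at the same limit: the limit of < 3 mL.min-1.g-1 in this assay, at which 2 of the 3 values shown sit. With the 4-chlorophenyl group held constant, methyl in place of phenyl on an aromatic carbon gives an at least 5.3-fold lower number from compound 1 to compound 3 (0.72 log units; beyond the scatter), so the one readable difference in clearance among these compounds goes with that other place on the shared core and not with the chloro.

Whether chloro and methoxy differ at all remains open, since the compounds shown offer no pair with this change on the core of compound 1, where clearance stands clear of the limit. Equally open, as far as these compounds go, is how an amine or a nitrile would read on an aromatic carbon para to a large group, and whether any group there would move clearance away from the limit.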